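The source may report more compounds than this note shows. Statements on the series, on what has been measured and on what is new or still open speak of the compounds shown alone.

Measured so far in an ADME assay on microsomes from liver (Homo sapiens) for metabolic stability, tested at 2.5 uM; on this read-out higher numbers stand for fast clearance and lower numbers for slow clearance:
compound 1, `O=S(=O)(c1ccc(F)cc1)c1cnc2c(F)cccc2c1-c1cccc(Cl)c1`, gives 1.21 mL/min
compound 2, `O=S(=O)(c1cc(Cl)cc(Cl)c1)c1cnc2c(F)cccc2c1-c1cccc(F)c1`, gives 1.08 mL/min

Two compounds carry a number in this assay, and the two numbers lie within the usual scatter of each other; nothing separates compound 1 from compound 2 on this read-out. Compound 2 is the starting point for the next pair.

Compound 3, `O=S(=O)(c1cc(Cl)cc(Cl)c1)c1cnc2c(F)cccc2c1-c1cccc(Cl)c1`, differs from compound 2 by chloro in place of fluoro on an aromatic carbon. Among the compounds with values here, no measured pair shows this same change, so the size of its step is unknown here. The expectation for this assay is a step no larger than the scatter, if anything toward a higher number: from compound 2 to compound 3 an estimated 1.3-fold higher number from compound 2 to compound 3 (0.11 log units; within the scatter).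

For compound 3 the expected result in this assay is 1.4 mL/min, with a range from 0.8 mL/min to 2.5 mL/min.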

Compound 3, intrinsic clearance in a liver preparation (reported as CLH), per the amount of preparation that the assay uses: 1.2 mL/min
The estimate for compound 3 lay 1.2-fold (0.07 log units) above the measured number; the measured number falls inside the stated range.
By their numbers in this assay, from the lowest: compounds 2, 3 and 1 (each within the scatter of the next).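

In this assay, the exchange of 3-fluorophenyl for 3-chlorophenyl now has a measured size: a 1.1-fold higher number from compound 2 to compound 3 (0.05 log units; within the scatter), which is within the scatter. The substituent on the sulfonyl sulfur also has a measured step, with 3,5-dichlorophenyl in place of 4-fluorophenyl giving a 1.0-fold lower number from compound 1 to compound 3 (0.00 log units; within the scatter), again within the scatter. No supporting data are available to explain either step.

As far as these compounds go, only halogen-bearing phenyl groups are compared here, so it remains open whether a methoxy group, an amine or a carboxylic acid at either place would move the clearance read-out beyond the scatter. From the compounds shown here alone, the contribution of the shared core also remains open, as it is the same in all three compounds.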